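This account rests on a few compounds, and the source may have more. Where it says the series, first, only, none or still open, it means among the compounds named here.

Measured so far in a functional assay on U-251 cells (Homo sapiens) for cytotoxicity; on this read-out higher numbers stand for weaker inhibition of growth and lower numbers for stronger inhibition of growth:
compound 1 `COc1ccc(C2=C(c3ccc(SC)cc3)CC3CCCN3C2=O)cc1O`: 5000 nM
compound 2 `COc1ccc(C2=C(c3ccc(SC)cc3)CC3CCCN3C2=O)cc1OC(=O)C1CCCN1C(=O)OC(C)(C)C`: 2000 nM
compound 3 `CSc1ccc(C2=C(c3ccc(F)c(F)c3)C(=O)N3CCCC3C2)cc1`: 15000 nM

Compound 3 has the highest number of the three in this assay, so it shows the weakest inhibition of growth in this small set. Compound 1 lies nearest to it and compound 2 furthest.

The next compound is compound 4 `CSc1ccc(C2=C(c3ccc(F)c(C)c3)C(=O)N3CCCC3C2)cc1`, which differs from compound 3 by methyl in place of fluoro on an aromatic carbon. This changes 3,4-difluorophenyl to 4-fluoro-3-methylphenyl, with methyl in place of fluoro on an aromatic carbon.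

Within the data shown here, only one measured step touches this aryl group: a 3.0-fold higher number from compound 1 to compound 3 (0.48 log units; beyond the scatter). Among the measured compounds shown here, that step replaced 3-hydroxy-4-methoxyphenyl with 3,4-difluorophenyl, so both groups on the ring differed, whereas here only one changes. For the measured compounds named here, no measured pair isolates methyl against fluoro. On these data alone, a smaller step than that one is therefore expected, quite possibly none beyond the scatter, and the direction stays open.

The expected change is a 1.2-fold lower number from compound 3 to compound 4 (0.06 log units; within the scatter). For compound 4 the estimate is 13000 nM, with an expected range of 6000 nM to 30000 nM.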

Compound 4, concentration for 50% growth inhibition: 200 nM
For compound 4 the middle estimate is 65-fold (1.81 log units) above the measured one; measured number outside the range, below it.
By their numbers in this assay, from the lowest: compound 4; then compound 2; then compound 1; then compound 3.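

In this assay the aromatic carbon ortho to a fluoro group proves highly sensitive: methyl in place of fluoro, one heavy atom for one heavy atom, gives a 75-fold lower number from compound 3 to compound 4 (1.88 log units; beyond the scatter) as a large step, well beyond the modest 3.0-fold higher number from compound 1 to compound 3 (0.48 log units; beyond the scatter) where both ring groups differed. Measured against the 3-hydroxy-4-methoxyphenyl group, 4-fluoro-3-methylphenyl gives a 25-fold lower number from compound 1 to compound 4 (1.40 log units; beyond the scatter) in the opposite direction to 3,4-difluorophenyl, so the choice of aryl group can move the number either way. No evidence is available on what lies behind this single-atom effect.

On these data alone, whether the gain is specific to methyl or extends to a chloro atom, an ethyl group or a trifluoromethyl group on the same carbon stays open. Also open, as far as these compounds go, is whether the fluoro group ortho to this carbon is needed for the low number seen with compound 4.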